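The source may report more compounds than this note shows. Statements on the series, on what has been measured and on what is new or still open speak of the compounds shown alone.

Working notes on the series. The shared core is varied at a single aromatic carbon. Compound 1 `CNc1nc(N)c2nc(O)n(Cc3ccccc3)c2n1` carries methylamino there, and in a functional assay (spleen, spleen) for activation, with Mus musculus as the target (a higher number here means that more compound is needed for the effect, a lower number that less compound is needed), compound 1 gives 1 uM. Compound 2 `Nc1nc(SCc2ccccc2)nc2c1nc(O)n2Cc1ccccc1` carries benzylsulfanyl, and compound 2 gives 0.1 uM. Compound 3 `CCCCCOc1nc(N)c2nc(O)n(Cc3ccccc3)c2n1` carries pentyloxy, and compound 3 gives 0.01 uM, the lowest of the three numbers. The measured steps are a 10-fold lower number from compound 1 to compound 2 (1.00 log units; beyond the scatter), a 100-fold lower number from compound 1 to compound 3 (2.00 log units; beyond the scatter) and a 10-fold lower number from compound 2 to compound 3 (1.00 log units; beyond the scatter), each beyond the scatter.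

Compound 4 `CCCC[S+]([O-])c1nc(N)c2nc(O)n(Cc3ccccc3)c2n1` is not yet measured. It differs from compound 3 as follows: a group of 6 heavy atoms (4 carbon, 1 oxygen, 1 sulfur; no ring) in place of a group of 6 heavy atoms (5 carbon, 1 oxygen; no ring), on an aromatic carbon. Among the measured compounds shown here, the steps that bear on this are a 100-fold lower number from compound 1 to compound 3 (2.00 log units; beyond the scatter) and a 10-fold lower number from compound 2 to compound 3 (1.00 log units; beyond the scatter): both moves into pentyloxy lowered the number, so a move out of pentyloxy is expected to raise it. For the measured compounds named here, the entering group has no measured precedent, so the size is uncertain. Compound 4 is estimated at 0.1 uM, within 0.02 uM to 0.5 uM. The expected step is a 10-fold higher number from compound 3 to compound 4 (1.00 log units; beyond the scatter).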

Compound 4, minimum effective concentration: 0.01 uM
Compound 4: middle estimate off by 10-fold (1.00 log units), on the high side, and the stated range ends above it.
By their numbers in this assay, from the lowest: compounds 3 and 4 (each within the scatter of the next); then compound 2; then compound 1.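

At this aromatic carbon, in this assay, pentyloxy gives way to the group of 6 heavy atoms holding 4 carbon, 1 oxygen and 1 sulfur with no change at the digits printed from compound 3 to compound 4 (within the scatter), so the low number of compound 3 does not depend on pentyloxy alone. The new group also matches pentyloxy in its standing against the other two compounds, with a 10-fold lower number from compound 2 to compound 4 (1.00 log units; beyond the scatter) and a 100-fold lower number from compound 1 to compound 4 (2.00 log units; beyond the scatter), which shows that an oxygen-linked chain is not required at this position. No supporting data explain why the two groups read alike.

Still open, going by these compounds, is whether the same four-carbon chain joined through a plain sulfur atom, or through a sulfone, would read alike. A longer or shorter chain on the sulfur-bearing group, or a carboxylic acid at this carbon, also remains untested by the compounds shown here.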